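Dimethyl for difluoro on the cyclohexylamine arm

The source may report more compounds than this note shows. Statements on the series, on what has been measured and on what is new or still open speak of the compounds shown alone.

Three members of this series have been run in a functional assay on cells for agonist activity at C-X-C chemokine receptor type 4 (Homo sapiens), read by fluorescence and calcium flux, with a stated time of 90 s (on this read-out lower numbers stand for an effect already at smaller amounts and higher numbers for an effect only at larger amounts of compound), none with a number. Compound 1 `c1ccc(CN(CCCCN(C[C@H]2Cc3ccccc3CN2)[C@H]2CCCc3cccnc32)Cc2ccccc2)cc1` gives > 30000 nM, a limit of the assay. Compound 2 `c1ccc2c(c1)CN[C@@H](CN(CCCCNCC1CCOCC1)[C@H]1CCCc3cccnc31)C2` gives > 30000 nM, again a limit. Compound 3 `FC1(F)CCC(NCc2ccc(CN(C[C@H]3Cc4ccccc4CN3)[C@H]3CCCc4cccnc43)cc2)CC1` gives > 30000 nM, also a limit. Compound 3 thus stands at the limit of > 30000 nM in this assay, at which 3 of the 3 values shown sit. Compound 4 `CC1(C)CCC(NCc2ccc(CN(C[C@H]3Cc4ccccc4CN3)[C@H]3CCCc4cccnc43)cc2)CC1` differs from compound 3 by 4,4-dimethylcyclohexyl in place of 4,4-difluorocyclohexyl on an amine nitrogen. Among the measured compounds shown here, no measured pair sets a reference for this change. With every measured value sitting at the limit, no step beyond the scatter is expected in this assay, a step that the limit leaves unreadable from compound 3 to compound 4. Compound 4 is expected to give 40000 nM in this assay, within 12000 nM to 150000 nM, most probably reported again only as a limit.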

Compound 4, half-maximal effective concentration: > 30000 nM
Compound 4 gave a limit, no number; the forecaster's own chance of this, stated with the estimate: 80%; the middle value lies beyond the limit too.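

Compound 3 and compound 4 both give only a limit in this assay, so no step between them can be read: the limit of > 30000 nM in this assay, at which 4 of the 4 values shown sit.

The compounds shown leave open how 4,4-dimethylcyclohexyl and 4,4-difluorocyclohexyl compare, and whether any member of this series gives a readable number.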